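Shortening the hydroxamate chain on a shared core

A few compounds are considered here, and "the series" means these few. Any claim that something is new, unique, unknown or untested is made for them only; others in the source may bear on it.

Compound 3 `Nc1ncnc2c1c(-c1cnc3[nH]ccc3c1)nn2CCCCCC(=O)NO` is one of three compounds on the same core tested in a functional assay on CNE-2 cells (Homo sapiens) for inhibition, read by MTT assay, with a stated time of 72 h; on this read-out higher numbers stand for weaker inhibition and lower numbers for stronger inhibition. In this assay compound 3 reaches only a limit, > 50000 nM. Compound 1 `Nc1ncnc2c1c(-c1cnc3[nH]ccc3c1)nn2CCCC(=O)NO` likewise gives only a limit, > 150000 nM. For the measured compounds named here, compound 2 `Nc1ncnc2c1c(-c1cnc3[nH]ccc3c1)nn2CCCCCCC(=O)NO` gives 19500 nM, the one firm number among the three. Compound 4 `Nc1ncnc2c1c(-c1cnc3[nH]ccc3c1)nn2CC(=O)NO` has not been measured; it carries hydroxycarbamoyl in place of 4-(hydroxycarbamoyl)butyl on a saturated chain carbon bound to an aromatic nitrogen. The measured steps that bear on this change both concern the length of the chain ending in the hydroxamic acid: an at least 7.6-fold lower number from compound 1 to compound 2 (0.88 log units; beyond the scatter) when the chain grows longer, and an at least 2.5-fold higher number from compound 2 to compound 3 (0.40 log units; beyond the scatter) when it shrinks. Both point the same way, longer chains toward stronger inhibition and shorter chains toward weaker, and compound 4 has the shortest chain of the four. With compound 3 already at its limit of > 50000 nM, a still weaker result is expected for compound 4, and a limit again is likely. For compound 4 the expected step is a step that the limit leaves unreadable from compound 3 to compound 4. The estimate for compound 4 is 150000 nM, with a range from 50000 nM to 500000 nM.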

Compound 4, half-maximal inhibitory concentration: > 150000 nM
Compound 4 gave a limit, no number; the forecaster's own chance of this, stated with the estimate: 85%; the middle value lies on the limit itself.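

In this assay compound 4 reaches only a limit, > 150000 nM. Set against the only firm value in the series, the change to the shortest chain gives an at least 7.6-fold higher number from compound 2 to compound 4 (0.88 log units; beyond the scatter), so the 5-(hydroxycarbamoyl)pentyl chain of compound 2 remains the only chain here with a measurable result. The steps to compound 4 from compound 1 and from compound 3 cannot be read, since limits stand at both ends and the shorter chains therefore cannot be ranked against one another: the limit of > 150000 nM in this assay, at which 2 of the 4 values shown sit.

The compounds shown leave open whether a longer chain than the 5-(hydroxycarbamoyl)pentyl of compound 2 would lower the number further. They also leave open how a carboxylic acid in place of the hydroxamic acid at the chain end would read in this assay.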